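This account rests on a few compounds, and the source may have more. Where it says the series, first, only, none or still open, it means among the compounds named here.

Values in an ADME assay on HEK293 cells (Homo sapiens) for cytotoxicity, read by resazurin assay, with a stated time of 48 h (a lower number here means that less compound is tolerated, a higher number that more compound is tolerated), are as follows:

- compound 1 `O=S(=O)(Nc1ccc(-c2nc3ccccc3o2)cc1)c1ccc(F)c(C(F)(F)F)c1` gives 82000 nM as a measured number
- compound 2 `CS(=O)(=O)Nc1ccc(-c2nc3ccccc3o2)cc1` gives > 100000 nM as a limit
- compound 3 `O=S(=O)(Nc1ccc(-c2nc3ccccc3o2)cc1)c1ccc(O)cc1` gives > 100000 nM as a limit

Compound 3 therefore stands at a limit, not at a number. The next compound, compound 4 `O=S(=O)(Nc1ccc(-c2nc3ccccc3o2)cc1)c1ccc(F)cc1`, differs from it as follows: fluoro in place of hydroxy on an aromatic carbon, para to a large group. Among the compounds with values here, the only measured step, a step that the two limits leave unreadable from compound 2 to compound 3, gives no size to build on. Compound 1 also carries a fluoro group and gives 82000 nM as a number, so a result close to that number is expected. The expected change, an at least 1.0-fold lower number from compound 3 to compound 4 (0.02 log units; that floor lies within the scatter), is none beyond the scatter, and any drift would more likely be downward. Compound 4 is estimated at 95000 nM, with an expected range from 45000 nM to 200000 nM overall.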

Compound 4, half-maximal cytotoxic concentration: > 100000 nM
Compound 4 was reported as a limit; the forecaster's own chance of this, stated with the estimate: 55%; at least 1.0-fold (0.02 log units) between middle value and limit.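

In this assay, compound 4 shows that a lone fluoro on this aromatic carbon, para to a large group, still gives a limit and not a number, as hydroxy does in compound 3. Hydrogen in place of trifluoromethyl gives an at least 1.2-fold higher number from compound 1 to compound 4 (0.08 log units; that floor lies within the scatter), so no effect of that group can be claimed. The steps among compound 2, compound 3 and compound 4 cannot be read, because all three share one limit: the limit of > 100000 nM in this assay, at which 3 of the 4 values shown sit.

As far as these compounds go, whether an amine or a carboxylic acid at this position would give a number remains open. So does the true distance of compound 3 and compound 4 from that limit.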